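The compounds below may be only part of what the source reports. "The series", "measured", "known", "first", "only" and "open" are said of these compounds alone.

Measured in a functional assay on K562 cells (Homo sapiens) for cytotoxicity, read by flow cytometry, with a stated time of 72 h; on this read-out lower numbers stand for stronger inhibition and higher numbers for weaker inhibition:
- compound 1 `Cc1ccc(S(=O)(=O)Cc2nc(Nc3cccc(C(F)(F)F)c3)c3ccccc3n2)cc1`; compound 1 gives > 25000 nM, a limit of the assay rather than a number.
- compound 2 `Cc1ccc(S(=O)(=O)Cc2nc(Nc3ccc(F)cc3)c3ccccc3n2)cc1`; compound 2 gives > 20000 nM, likewise a limit.
- compound 3 `Cc1ccc(S(=O)(=O)Cc2nc(Nc3cccc(C(F)(F)F)c3)c3cc([N+](=O)[O-])ccc3n2)cc1`; compound 3 gives > 125000 nM, again a limit.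

Compound 4 `Cc1ccc(S(=O)(=O)Cc2nc(Nc3ccc(F)cc3)c3cc([N+](=O)[O-])ccc3n2)cc1` has not been measured in this assay. The change from compound 3 to compound 4 is 4-fluorophenyl in place of 3-(trifluoromethyl)phenyl on a nitrogen on an aromatic ring. The same change occurs between the two measured compounds as 4-fluorophenyl in place of 3-(trifluoromethyl)phenyl on a nitrogen on an aromatic ring, where the step is a step that the two limits leave unreadable from compound 1 to compound 2. The two cores differ by nitro in place of hydrogen on an aromatic carbon, and that step is a step that the two limits leave unreadable from compound 1 to compound 3. With every value sitting at a limit (the limit of > 25000 nM in this assay, at which 1 of the 3 values shown sits, (the limit of > 20000 nM in this assay, at which 1 of the 3 values shown sits), (the limit of > 125000 nM in this assay, at which 1 of the 3 values shown sits)), no step size can be read anywhere in this set, and nothing points to a change in either direction.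

For compound 4 the estimate in this assay is 100000 nM, within 20000 nM and 300000 nM, most likely again reported as a limit. The expected step from compound 3 is an at least 1.2-fold lower number from compound 3 to compound 4 (0.09 log units; that floor lies within the scatter), resting only on compound 1 and compound 2 both giving limits after the same change.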

Compound 4, half-maximal inhibitory concentration: > 125000 nM
Compound 4: only a limit was reported (the forecaster's own chance of this, stated with the estimate: 90%); middle value at least 1.2-fold (0.09 log units) away from the limit.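

In this assay compound 4 gives > 125000 nM, which is a limit of the assay. All values are limits, so the steps from compound 3 and compound 2 to compound 4 cannot be read. The compounds shown leave open whether either change alters cytotoxicity at all.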